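This account rests on a few compounds, and the source may have more. Where it says the series, first, only, none or still open, it means among the compounds named here.

Measured in an ADME assay on a cell-free system (plasma, Homo sapiens); a higher number here means a larger unbound share of the compound, a lower number a smaller unbound share:
- compound 1 `CCNC(=O)Nc1nc2cc(-c3cccnc3)c(=O)n(CCC(C)C)c2s1`: 0.06
- compound 2 `CCNC(=O)Nc1nc2cc(-c3cncnc3)c(=O)n(C(C)C)c2s1`: 0.15

Compound 2 has the higher of the two numbers, and the gap to compound 1 lies beyond the scatter. Within the data shown here, the two compounds differ in more than one place, so they give no clean step. Compound 3 `CCNC(=O)Nc1nc2cc(-c3ccc(C#N)nc3)c(=O)n(C(C)C)c2s1` follows from compound 2 through one change, 6-cyanopyridin-3-yl in place of pyrimidin-5-yl on an aromatic carbon. Among the measured compounds shown here, no measured pair covers this change, so the expectation in this assay is tentative: a modest fall, a 1.7-fold lower number from compound 2 to compound 3 (0.22 log units; within the scatter), close to the scatter. For compound 3 the estimated value is 0.09, with an expected range of 0.05 to 0.16.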

Compound 3, unbound fraction: 0.04
Beside the measured number, compound 3's estimate is 2.3-fold (0.35 log units) above it; measured number outside the range, below it.
By their numbers in this assay, from the lowest: compounds 3 and 1 (each within the scatter of the next); then compound 2.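

Among these compounds, on the isopropyl compounds, 6-cyanopyridin-3-yl in place of pyrimidin-5-yl gives the first clean step in this assay (a 3.8-fold lower number from compound 2 to compound 3 (0.57 log units; beyond the scatter)). This aromatic carbon therefore influences the unbound share, even though the count of hydrogen-bond acceptors stays the same across the change. No available evidence bears on the reason for the fall.

The change alters both the ring and the nitrile, so the compounds shown cannot separate the two contributions. On these data alone, whether an amine or a carboxylic acid on this ring would raise the unbound share remains open.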